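The compounds below may be only part of what the source reports. "The series", "measured", "known", "first", "only" and "open" are said of these compounds alone.

Measured compounds in an assay on CHO cells for displacement of a labelled ligand from prostaglandin E2 receptor EP1 subtype (Mus musculus), read by scintillation counting, with a stated time of 20 min; a lower number here means a stronger inhibitor, a higher number a weaker inhibitor:
Compound 1 `O=C(O)CCCSCCN1C(=O)CC[C@@H]1/C=C/[C@@H](O)Cc1cccc(-c2ccc3[nH]ccc3c2)c1` sits at a limit of the assay, > 10000 nM.
Compound 2 `O=C(O)CCCSCCN1C(=O)CC[C@@H]1/C=C/[C@@H](O)Cc1cccc(-c2cc3ccccc3o2)c1` also sits at a limit, > 10000 nM.
Compound 3 `O=C(O)c1csc(SCCN2C(=O)CC[C@@H]2/C=C/[C@@H](O)Cc2cccc(-c3ccccc3)c2)n1` gives 4200 nM.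

Going by the values given here, compound 3 thus carries the only number in this assay; the other two values are limits (the limit of > 10000 nM in this assay, at which 2 of the 3 values shown sit), so the step that the two limits leave unreadable from compound 1 to compound 2 cannot be read. Compound 4 `Cc1cccc2oc(-c3cccc(C[C@H](O)/C=C/[C@H]4CCC(=O)N4CCSc4nc(C(=O)O)cs4)c3)nc12` differs from compound 3 in one place: 4-methyl-1,3-benzoxazol-2-yl in place of phenyl on an aromatic carbon. Among the compounds with values here, no measured step touches this change; the one measured step is unreadable, and compounds 1 and 2 differ from compound 3 in more than one place, so they give no bearing on it. The step of a 1.4-fold higher number from compound 3 to compound 4 (0.15 log units; within the scatter) is therefore expected to lie within the scatter or to run somewhat weaker, with a real chance of a limit. Compound 4 is estimated at 6000 nM, range 2000 nM to 20000 nM.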

Compound 4, inhibition constant: 7700 nM
Compound 4: middle estimate off by 1.3-fold (0.11 log units), on the low side; the range from low to high includes it.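

In this assay, 4-methyl-1,3-benzoxazol-2-yl in place of phenyl on an aromatic carbon gives a 1.8-fold higher number from compound 3 to compound 4 (0.26 log units; within the scatter). This position therefore takes the two-ring group, with its 2 hydrogen-bond acceptors, without a change beyond the scatter, and compound 4 remains a measured number. Compound 1 and compound 2 stay at a limit, and the step between them cannot be read: the limit of > 10000 nM in this assay, at which 2 of the 4 values shown sit.

Open, going by these compounds, is whether an amine or a carboxylic acid at this position would move the number beyond the scatter. Also open, on these data alone, is what the methyl group of compound 4 contributes.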